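Amide Nitrogen Substituents in a Rat Paw Edema Series

The source may report more compounds than this note shows. Statements on the series, on what has been measured and on what is new or still open speak of the compounds shown alone.

Compound 1 `COc1cc2c(cc1OC)C(CC(N)=O)CC2`: 26.7%
Compound 2 `CNC(=O)CC1CCc2cc(OC)c(OC)cc21`: 33.3%
Compound 3 `COc1cc2c(cc1OC)C(CC(=O)NC1CCCC1)CC2`: 46.7%

The three measured compounds share one core and differ only in what sits on the amide-type nitrogen. In a functional assay on the whole organism (strain Wistar) for inhibition, with Rattus norvegicus as the target, read by paw edema, with stated times of 60 min and 24 h, at a dose of 100 mg/kg by the oral route (on this read-out higher numbers stand for more inhibition at the one dose given (going by the name of the read-out) and lower numbers for less inhibition), compound 1 gives 26.7%, compound 2 gives 33.3% and compound 3 gives 46.7%. Compound 3 thus stands highest of the three, and its distance from each of the other two is beyond the scatter.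

Compound 4 `COc1cc2c(cc1OC)C(CC(=O)N1CCNCC1)CC2` is the next step from compound 3. The change is piperazin-1-yl in place of cyclopentylamino on a carbonyl carbon. Among the compounds with values here, two measured steps bear on this position: a number 20 percentage points higher from compound 1 to compound 3 (beyond the scatter) and a number 13.4 percentage points higher from compound 2 to compound 3 (beyond the scatter), both modest. Both describe an enlargement of the group on the amide-type nitrogen, whereas the step to compound 4 exchanges the whole cyclopentylamino group for piperazin-1-yl on the carbonyl carbon, keeping a ring of comparable size but with two nitrogens in it. Within the data shown here, no measured step covers a change of this kind, so the direction is uncertain; the account therefore expects compound 4 to land somewhere between compound 2 and compound 3, that is, a step of a number 8.7 percentage points lower from compound 3 to compound 4 (within the scatter). Compound 4 is estimated at 38%, in the range 24% to 52%.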

Compound 4, a percentage reported as inhibition, in the whole organism at one dose (the size of the read-out at that dose, not a potency): 65%
Compound 4: the middle estimate sits 27 percentage points below what was measured, and the stated range ends below it.
By their numbers in this assay, from the lowest: compounds 1 and 2 (each within the scatter of the next); then compound 3; then compound 4.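

In this assay the change to piperazin-1-yl gives a number 18.3 percentage points higher from compound 3 to compound 4 (beyond the scatter) and so extends the climb seen with the earlier amides, together with a number 31.7 percentage points higher from compound 2 to compound 4 (beyond the scatter) and a number 38.3 percentage points higher from compound 1 to compound 4 (beyond the scatter) as the two large steps of the set. The earlier compounds shown here tied higher numbers only to groups on the amide-type nitrogen that grew from amino through methylamino to cyclopentylamino, whereas cyclopentylamino and piperazin-1-yl both have 6 heavy atoms, so this rise comes with no change in that count and shows that growth in heavy atoms is not needed for a higher number at this carbonyl carbon. What does change is the ring, from a five-membered non-aromatic ring of carbon only to a six-membered non-aromatic ring with 2 hetero atoms, and no measurement at hand explains why this exchange raises the number. The compounds shown leave open whether the gain follows the larger ring or the second ring nitrogen, a question that piperidin-1-yl or morpholin-4-yl on the same carbonyl carbon would separate. They also leave open what a substituent on the free piperazine nitrogen, such as a methyl or acetyl group, would do to the read-out at this one dose.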